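Chloro-to-hydrogen step on the fused core of compound 3

A few compounds are considered here, and "the series" means these few. Any claim that something is new, unique, unknown or untested is made for them only; others in the source may bear on it.

Measured so far in a functional assay on M14 cells (Homo sapiens) for cytotoxicity, read by sulforhodamine B assay, with a stated time of 48 h; on this read-out lower numbers stand for higher toxicity in this test and higher numbers for lower toxicity in this test:
compound 1 `Nc1nc(Cl)c2ncn(Cc3ccccc3CCl)c2n1`: > 100000 nM
compound 2 `ClCc1ccccc1Cn1cnc2ncnc(Cl)c21`: 27500 nM
compound 3 `ClCc1ccccc1Cn1cnc2c(Cl)nc(Cl)nc21`: 5750 nM

The value of compound 1 is a limit of this assay, not a number. Compound 3 has the lowest of the two numbers; the nearest is compound 2, whose value is a higher number, with a gap beyond the usual scatter. Among the measured compounds shown here, the one step measured within one place is an at least 17-fold lower number from compound 1 to compound 3 (1.24 log units; beyond the scatter); it can only be given as a lower bound because of the limit of > 100000 nM in this assay, at which 1 of the 3 values shown sits.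

Compound 4 `ClCc1ccccc1Cn1cnc2c(Cl)ncnc21` is not yet measured. It differs from compound 3 thus: hydrogen in place of chloro on an aromatic carbon. For the measured compounds named here, no measured step concerns a chloro leaving and a hydrogen entering; the step from compound 1 to compound 3 concerns a different group at that place and gives only the sense that this carbon matters. Compound 2 and compound 4 carry the same set of groups on differently joined cores, and compound 2 sits well above compound 3. The expectation for compound 4 is therefore a higher number than compound 3, a moderate step of a 2.6-fold higher number from compound 3 to compound 4 (0.42 log units; beyond the scatter). Compound 4 is expected at 15000 nM, within 5000 nM to 45000 nM.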

Compound 4, concentration lethal to 50% of the cells: 7240 nM
Compound 4: middle estimate off by 2.1-fold (0.32 log units), on the high side; the measured number falls inside the stated range.
By their numbers in this assay, from the lowest: compounds 3 and 4 (each within the scatter of the next); then compound 2. At a limit, above all of these: compound 1.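

In this assay, a 1.3-fold higher number from compound 3 to compound 4 (0.10 log units; within the scatter) shows that this carbon between two ring nitrogen atoms tolerates loss of the chloro group, with hydrogen and chloro not told apart by this read-out. With hydrogen in place of amino, the series gives an at least 13-fold lower number from compound 1 to compound 4 (1.14 log units; beyond the scatter), so among these compounds the earlier large step does not depend on chloro entering at this carbon: it appears with either replacement of the amino group. Compound 1 stands at a limit of the assay, so both steps from it are bounds only: the limit of > 100000 nM in this assay, at which 1 of the 4 values shown sits.

Open, from the compounds shown here alone, is whether a methoxy or a methylamino group at this carbon would fall with compound 1 or with compound 3 and compound 4. Also open, going by these compounds, is whether the amino result would hold if the remaining chloro group on the shared core were replaced by a methyl group.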